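The compounds below may be only part of what the source reports. "The series", "measured", "known", "first", "only" and "open" are said of these compounds alone.

In a functional assay on HCT-116 cells (Homo sapiens) for cytotoxicity, with a stated time of 48 h (a higher number here means a weaker inhibitor, a lower number a stronger inhibitor), compound 1 `COc1ccc(C2=C(c3ccc(OC)cc3)C(=O)N3CCCC3C2)cc1` gives 3200 nM. For compound 2 `COc1ccc(C2=C(c3cccc(N)c3)C(=O)N3CCCC3C2)cc1` this assay returns only a limit, > 25000 nM. Among the measured compounds shown here, the one measured step, an at least 7.8-fold higher number from compound 1 to compound 2 (0.89 log units; beyond the scatter), weakens inhibition markedly. Compound 3 `O=C1C(c2ccccc2)=C(c2ccc(O)cc2)CC2CCCN12` gives 9000 nM, the highest of the two actual numbers; its nearest neighbour is compound 1, whose number lies lower by more than the scatter. Compound 4 `O=C1C(c2ccccc2)=C(c2ccc(OCc3ccccc3)cc2)CC2CCCN12` differs from compound 3 by benzyl in place of hydrogen on an oxygen on an aromatic ring. For the measured compounds named here, no measured step touches the oxygen on the aromatic ring, and the single measured step concerns a different position, so it offers no direct guide. For compound 4 the expected step is a 1.1-fold higher number from compound 3 to compound 4 (0.05 log units; within the scatter), not clearly beyond the scatter. Compound 4 is therefore estimated at 10000 nM, between 3000 nM and 30000 nM.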

Compound 4, half-maximal inhibitory concentration: 8900 nM
For compound 4 the middle estimate is 1.1-fold (0.05 log units) above the measured one; the measured number falls inside the stated range.
By their numbers in this assay, from the lowest: compound 1; then compounds 4 and 3 (each within the scatter of the next). At a limit, above all of these: compound 2.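

In this assay the change reads as a 1.0-fold lower number from compound 3 to compound 4 (0.00 log units; within the scatter), so going from hydroxy to benzyloxy on this oxygen on an aromatic ring leaves the number within the scatter. Among the compounds shown here, this is the first measured change at this oxygen, and it shows that the free hydroxy is not needed to keep this level of cytotoxicity, at least when benzyl replaces its hydrogen. Nothing shown accounts for this outcome. Open, going by these compounds, is whether a methyl ether, an amine or a carboxylic acid on this oxygen would behave likewise.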